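This account rests on a few compounds, and the source may have more. Where it says the series, first, only, none or still open, it means among the compounds named here.

Working notes on the series. In a physicochemical assay for lipophilicity, at pH 7.4 (a higher number here means a more lipophilic compound, a lower number a more polar compound), compound 1 `CNC(=O)c1cc(C(=O)N[C@H]2[C@@H]3COC[C@@H]32)cc2c1OC[C@H]2c1ccccc1` gives 3.3 on the shared core, compound 2 `CNC(=O)c1cc(C(=O)N[C@H]2[C@@H]3C[C@@H](O)C[C@@H]32)cc2c1OC[C@H]2c1ccccc1` gives 2.9 on the same core, and compound 3 `CNC(=O)c1cc(C(N)=O)cc2c1OC[C@H]2c1ccccc1` gives 2.7 with the amide hydrogen in place. Two measured steps lead to that hydrogen, one beyond the scatter (a number 0.60 log units lower from compound 1 to compound 3 (beyond the scatter)) and one within it (a number 0.20 log units lower from compound 2 to compound 3 (within the scatter)). Compound 3 therefore stands lower than compound 1 only, and its value cannot be told apart from that of compound 2.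

Compound 4 `CNC(=O)c1cc(C(=O)Nc2cnn(C)c2)cc2c1OC[C@H]2c1ccccc1` differs from compound 3 by 1-methyl-1H-pyrazol-4-yl in place of hydrogen on an amide-type nitrogen in the form of 1-methyl-1H-pyrazol-4-yl in place of hydrogen on an amide-type nitrogen. The two steps above, read in reverse, are the closest guide, and they range from nothing beyond the scatter to a modest move. For the measured compounds named here, the two groups in those steps also differ from each other (a number 0.40 log units lower from compound 1 to compound 2 (beyond the scatter)), and no measured compound carries an aromatic ring on that nitrogen, so the read-across is loose. A modest rise is expected in this assay for this change, though a result within the scatter would not surprise. The step expected here is (a number 0.40 log units higher from compound 3 to compound 4 (beyond the scatter)). For compound 4 the estimated value is 3.1 (expected range 2.7 to 3.5).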

Compound 4, distribution coefficient: 3.5
For compound 4 the middle estimate is 0.40 log units below the measured one, within the range that was stated.
By their numbers in this assay, from the lowest: compounds 3 and 2 (each within the scatter of the next); then compounds 1 and 4 (each within the scatter of the next).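

Compound 4 is the only compound shown with an aromatic ring on the amide-type nitrogen, and in this assay 1-methyl-1H-pyrazol-4-yl in place of hydrogen gives a number 0.80 log units higher from compound 3 to compound 4 (beyond the scatter), a step clearly beyond the scatter, whereas the group of compound 2 could not be told apart from hydrogen. This position therefore separates groups of similar size: a number 0.60 log units higher from compound 2 to compound 4 (beyond the scatter), while the group of compound 1 and 1-methyl-1H-pyrazol-4-yl cannot be told apart, with a number 0.20 log units higher from compound 1 to compound 4 (within the scatter). No measurement is available that would explain these steps.

The compounds shown leave open whether the step belongs to an aromatic ring on this nitrogen as such or to the particular ring nitrogens and methyl of 1-methyl-1H-pyrazol-4-yl, as only one aromatic group stands at this position. As far as these compounds go, how a phenyl group, or a chain ending in an amine or a carboxylic acid, would read on the same nitrogen in this assay also stays open.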